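The compounds below may be only part of what the source reports. "The series", "measured", "known", "first", "only" and "open" are said of these compounds alone.

Compound 3 `COc1nc(=O)ccn1[C@@H]1O[C@H](COP(=O)(O)OP(=O)(O)O)[C@@H](O)[C@H]1O` is the reference point here. In an in vitro functional assay on 1321-N1 cells for agonist activity at P2Y purinoceptor 6 (Homo sapiens), read by scintillation proximity assay and inositol phosphate accumulation (a higher number here means that more compound is needed for the effect, a lower number that less compound is needed), compound 3 gives 1370 nM, the lowest of the two numbers recorded. Its nearest neighbour is compound 1 `CSc1nc(=O)ccn1[C@@H]1O[C@H](COP(=O)(O)OP(=O)(O)O)[C@@H](O)[C@H]1O`, which in this assay gives 4700 nM; the step of a 3.4-fold lower number from compound 1 to compound 3 (0.54 log units; beyond the scatter) shows that exchanging one small group on the shared core moves the number by a modest but real amount. Compound 2 `CNc1nc(=O)ccn1[C@@H]1O[C@H](COP(=O)(O)O)[C@@H](O)[C@H]1O` carries a shorter phosphate chain, and in this assay compound 2 gives > 100000 nM, which is a limit of the assay rather than a number, as described by the limit of > 100000 nM in this assay, at which 1 of the 3 values shown sits.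

Compound 4 `CNc1nc(=O)ccn1[C@@H]1O[C@H](COP(=O)(O)OP(=O)(O)O)[C@@H](O)[C@H]1O` is the next step from compound 3: methylamino in place of methoxy on an aromatic carbon. Among the measured compounds shown here, the only measured step at this position, from compound 1 to compound 3, was modest. The methylamino group of compound 4 also appears in compound 2, but compound 2 differs in its phosphate chain as well, so its value cannot be read as a guide to this exchange. A change no larger than the one already seen is expected, with the direction uncertain; the estimated step is a 1.8-fold higher number from compound 3 to compound 4 (0.26 log units; within the scatter). Compound 4 is therefore expected to give about 2500 nM, within a range from 600 nM to 12000 nM.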

Compound 4, half-maximal effective concentration: > 100000 nM
Compound 4 ended at the assay's limit; the forecaster's own chance of this, stated with the estimate: 10%; middle value at least 40-fold (1.60 log units) away from the limit.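

In this assay, the position between two ring nitrogen atoms proves far less tolerant than the earlier step suggested: methylamino in place of methoxy gives an at least 72-fold higher number from compound 3 to compound 4 (1.86 log units; beyond the scatter), and methylamino in place of methylsulfanyl gives an at least 21-fold higher number from compound 1 to compound 4 (1.32 log units; beyond the scatter). Methoxy and methylamino have the same number of heavy atoms, yet methylamino brings 1 hydrogen-bond donor and methoxy brings none, although these compounds cannot show whether that difference is what matters. The result for compound 4 is a limit of the assay and not a number, and compound 2 also stands at a limit, so the step between these two compounds cannot be read and the effect of the phosphate chain on the methylamino compounds remains unknown: the limit of > 100000 nM in this assay, at which 2 of the 4 values shown sit.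

The compounds shown leave open whether a plain amine or a longer chain, such as ethoxy, would be accepted at this position. They also leave open how far beyond the limit compound 4 lies, so the full size of the loss on moving from methoxy to methylamino is not known.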